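Pyrazin-2-yl on the Ring Amine of Compound 3

A few compounds are considered here, and "the series" means these few. Any claim that something is new, unique, unknown or untested is made for them only; others in the source may bear on it.

Compound 3 `Nc1ccccc1NC(=O)c1ccc(CSC(=S)N2CCN(Cc3ccncc3)CC2)cc1` gives 72.9% in a functional assay on HeLa cells (Homo sapiens) for antiproliferative activity, read by CCK-8 assay, with a stated time of 72 h, tested at 8 uM (a lower number here means a weaker effect, a higher number a stronger effect of the compound at the concentration tested), the highest of the three numbers measured. Compound 2 `CN(Cc1cccnc1)C(=S)SCc1ccc(C(=O)Nc2ccccc2N)cc1` gives 68.7% in this assay, a value within the scatter of compound 3, while compound 1 `Nc1ccccc1NC(=O)c1ccc(CSC(=S)N2CCc3cc([N+](=O)[O-])ccc32)cc1` gives 43.6%, which lies beyond the scatter below compound 3. Compound 4 `Nc1ccccc1NC(=O)c1ccc(CSC(=S)N2CCN(c3cnccn3)CC2)cc1` has not yet been measured. It differs from compound 3 by pyrazin-2-yl in place of (pyridin-4-yl)methyl on an amine nitrogen in a ring. No step between measured compounds matches this change, so the expectation rests on the numbers shown alone. Because compound 3 gives 72.9%, compound 4 is expected to stay in the same region, with an estimated step of a number 7.9 percentage points lower from compound 3 to compound 4 (within the scatter) that does not go beyond the scatter. The estimate for compound 4 is 65%, expected to fall between 45% and 85%.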

Compound 4, a percentage reported as inhibition, at one concentration (the size of the read-out at that concentration, not a potency): 76.9%
For compound 4 the middle estimate is 11.9 percentage points below the measured one; low and high end bracket the measured number.
By their numbers in this assay, from the lowest: compound 1; then compounds 2, 3 and 4 (each within the scatter of the next).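

With pyrazin-2-yl in place of (pyridin-4-yl)methyl on the amine nitrogen in the ring, this assay shows a number 4 percentage points higher from compound 3 to compound 4 (within the scatter) and so no separation between the two groups. This is the first one-place step among the compounds shown, and it indicates that this position accepts an aromatic ring with two hetero atoms attached directly to the nitrogen. No measured evidence bears on why the two groups read alike. On these data alone, whether a methyl group or a longer chain ending in a carboxylic acid would hold the read-out remains open. A read-out at one concentration also leaves open whether compound 3 and compound 4 differ in potency.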